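Methyl for hydroxy hydrogen on two oxindole-type cores

The source may hold more compounds than are shown below. What is called first, only, known or untested is meant among the compounds shown, and "the series" means these compounds.

Measured so far:
compound 1 `CCn1cc(C(=O)O)c(=O)c2cc(F)c(N3CCN(CN4C(=O)/C(=N\NC(=S)NO)c5cc(C)ccc54)C(C)C3)c(F)c21`: 244000 nM
compound 2 `CCN(CC)CN1C(=O)/C(=N\NC(=S)NO)c2cc(F)ccc21`: 521000 nM
compound 3 `CCn1cc(C(=O)O)c(=O)c2cc(F)c(N3CCN(CN4C(=O)/C(=N\NC(=S)NOC)c5cc(C)ccc54)C(C)C3)c(F)c21`: 156000 nM

The three compounds were tested in an ADME assay on MT4 cells (Homo sapiens) for cytotoxicity, read by spectrophotometry, with a stated time of 5 days; a lower number here means that less compound is tolerated, a higher number that more compound is tolerated. Compound 2 gives the highest number of the three; its steps to compound 1 and to compound 3 are both beyond the scatter. How the core of compound 2 differs from the core of compound 1 is not broken down here. Compound 1 and compound 3 share a core and differ in one place, (methyl in place of hydrogen on an oxygen), and this gave a 1.6-fold lower number from compound 1 to compound 3 (0.19 log units; within the scatter).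

Compound 4 `CCN(CC)CN1C(=O)/C(=N\NC(=S)NOC)c2cc(F)ccc21` has not yet been measured in this assay . It stands to compound 2 as compound 3 stands to compound 1: the difference is methyl in place of hydrogen on an oxygen, the same change at the same kind of place, an oxygen whose other neighbour is an amide-type nitrogen. For the measured compounds named here, the only guide is the single matched step from compound 1 to compound 3, which lay within the scatter, so the expected step from compound 2 to compound 4 is estimated at a 1.5-fold lower number from compound 2 to compound 4 (0.19 log units; within the scatter), small and downward, resting on the step of a 1.6-fold lower number from compound 1 to compound 3 (0.19 log units; within the scatter) as the one precedent. On that basis compound 4 is expected to give about 340000 nM in this assay , with a likely range from 160000 nM to 720000 nM, since one precedent on a different core leaves the direction uncertain.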

Compound 4, half-maximal cytotoxic concentration: 490000 nM
The estimate for compound 4 lay 1.4-fold (0.16 log units) below the measured number, within the range that was stated.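

In this assay, the new step is a 1.1-fold lower number from compound 2 to compound 4 (0.03 log units; within the scatter), so methyl in place of hydrogen on the oxygen gives no difference on this core that can be told from the scatter. Set beside the earlier step, the same change reads alike on the two cores: the same change on two cores in this assay, a 1.6-fold lower number (0.19 log units; within the scatter) from compound 1 to compound 3 and a 1.1-fold lower number (0.03 log units; within the scatter) from compound 2 to compound 4, 1.5-fold (0.17 log units) apart, within the scatter of two such steps This shows that hydroxyamino to methoxyamino carried over from the core of compound 1 to the core of compound 2 with neither step nor the gap between them beyond the scatter, but two matched pairs set no rule for the series, and they cannot exclude a small real difference between the cores or say why the two steps agree.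

The compounds shown leave open whether an ethyl, a benzyl or an acetyl group on this same oxygen would also give a step within the scatter, or whether the agreement is particular to methyl. They also leave open whether the change would read alike on a third core, for example one carrying a morpholine in place of the diethylamino group of compound 2, or in any assay other than this assay.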